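A few compounds are considered here, and "the series" means these few. Any claim that something is new, unique, unknown or untested is made for them only; others in the source may bear on it.

Measured so far:
compound 1 `C/C(=N/NC(=S)Nc1ccc([N+](=O)[O-])cc1)c1ccccn1`: 160 nM in a functional assay on U-87MG ATCC cells (Homo sapiens) for cytotoxicity, read by MTT assay, with a stated time of 48 h; on this read-out higher numbers stand for weaker inhibition and lower numbers for stronger inhibition
compound 2 `C/C(=N/NC(=S)Nc1ccc(F)cc1)c1ccccn1`: 10 nM in this assay
compound 3 `CC(=NNC(=S)Nc1ccc(F)cc1)c1ccccn1`: 10 nM in this assay

Compounds 2 and 3 share the same atoms and bonds; they differ only in that (the two compounds have the same atoms and bonds; at least one stereo element is drawn with a configuration in one of them and without one in the other: 1 of 1 stereo elements differ; a double bond is drawn Z in compound 2 and without a configuration in compound 3). In this assay this gives no change at the digits printed from compound 2 to compound 3 (within the scatter), so the two entries stand level, a point worth keeping in view given (the fact that one of compounds 2 and 3 is drawn with a defined configuration and the other without, at the place where they differ).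

Going by the values given here, the one substantive change among the measured compounds is nitro in place of fluoro on an aromatic carbon. In this assay it produces a 16-fold higher number from compound 2 to compound 1 (1.20 log units; beyond the scatter), a large step, and it leaves compound 1 as the highest of the three numbers.

Compound 4 `CC(=NNC(=S)Nc1ccc([N+](=O)[O-])cc1)c1ccccn1` is not yet measured. It relates to compound 3 exactly as compound 1 relates to compound 2: nitro in place of fluoro on an aromatic carbon. The place lines of the two changes read the same word for word, so this is the same change made on the core of compound 3 instead of the core of compound 2, the two cores differing only as described by the two compounds have the same atoms and bonds; at least one stereo element is drawn with a configuration in one of them and without one in the other: 1 of 1 stereo elements differ; a double bond is drawn Z in compound 2 and without a configuration in compound 3.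

Since compounds 2 and 3 sit level in this assay, the step from compound 3 to compound 4 is expected to be about the size of the earlier one, that is a 16-fold higher number from compound 3 to compound 4 (1.20 log units; beyond the scatter), because the same change gave a 16-fold higher number from compound 2 to compound 1 (1.20 log units; beyond the scatter). On that basis compound 4 is estimated at 160 nM in this assay, most likely between 60 nM and 400 nM.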

Compound 4, half-maximal inhibitory concentration: 160 nM
Compound 4: middle estimate and measured number agree at the digits printed; measured number inside the range.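

In this assay nitro in place of fluoro on an aromatic carbon gives a 16-fold higher number from compound 3 to compound 4 (1.20 log units; beyond the scatter) on the core of compound 3, and this step carries over between the two cores without a visible loss: the same change on two cores in this assay, a 16-fold higher number (1.20 log units; beyond the scatter) from compound 2 to compound 1 and a 16-fold higher number (1.20 log units; beyond the scatter) from compound 3 to compound 4, 1.0-fold (0.00 log units) apart, within the scatter of two such steps. The nitro pair repeats what the fluoro pair showed, with no change at the digits printed from compound 1 to compound 4 (within the scatter) in this assay as the reading across a difference that lies only in the drawing of the double bond: the fact that one of compounds 1 and 4 is drawn with a defined configuration and the other without, at the place where they differ. This shows that the change transfers between a core drawn with a defined configuration and the same core drawn without one, but it does not show transfer to any core that differs in atoms or bonds, and the drawings do not tell whether compound 3 and compound 4 are a single form or a mixture.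

The series shown holds only two groups at this place, so it remains open whether an amine, a methoxy group or a carboxylic acid on the same aromatic carbon would sit near the fluoro compounds or near the nitro compounds. Also open, going by these compounds, is whether the step would hold on a core with a longer chain in place of the methyl group of the shared core.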